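Working notes: amide side chains on the shared core

This account rests on a few compounds, and the source may have more. Where it says the series, first, only, none or still open, it means among the compounds named here.

Measured so far in a functional assay on CHO cells for agonist activity at Free fatty acid receptor 1 (Homo sapiens), read by a luciferase reporter; on this read-out higher numbers stand for larger maximal responses and lower numbers for smaller maximal responses:
compound 1, `Cc1nc(-c2ccc(C(F)(F)F)cc2)sc1CNc1ccc(C(C)CC(=O)O)cc1`: 109%
compound 2, `Cc1nc(-c2ccc(C(F)(F)F)cc2)sc1CNc1ccc(CCC(=O)NC(C)C)cc1`: 84%

Going by the values given here, compound 2 stands at the lowest of the two numbers in this assay; its only neighbour is compound 1, from which it is separated by a number 25 percentage points lower from compound 1 to compound 2 (beyond the scatter).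

Compound 3, `Cc1nc(-c2ccc(C(F)(F)F)cc2)sc1CNc1ccc([C@H]2C[C@@H]2C(N)=O)cc1`, differs from compound 2 by 2-carbamoylcyclopropyl in place of 2-(isopropylcarbamoyl)ethyl on an aromatic carbon. Among the compounds with values here, the one measured step, a number 25 percentage points lower from compound 1 to compound 2 (beyond the scatter), replaced a carboxylic acid with an amide and is therefore only a loose guide: compound 2 and compound 3 both carry an amide, and no measured step compares two amides. With nothing in the numbers pointing up or down, the expected step in this assay is a number 4 percentage points lower from compound 2 to compound 3 (within the scatter), which lies within the scatter. Compound 3 is thus estimated to give 80%, with a range from 55% to 105%.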

Compound 3, largest response reached (reported as percent of maximum), in percent of the reference or control that the assay uses: 80%
The estimate for compound 3 equals the measured number at the digits printed, and the stated range covers the measured number.
By their numbers in this assay, from the lowest: compounds 3 and 2 (each within the scatter of the next); then compound 1.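

Across the change from 2-(isopropylcarbamoyl)ethyl to 2-carbamoylcyclopropyl, the step in this assay is a number 4 percentage points lower from compound 2 to compound 3 (within the scatter), so at this position on the aromatic ring the open chain with its isopropyl amide and the three-membered ring with its unsubstituted amide cannot be told apart on this read-out. Compound 1 stays apart from this second amide as well, with a number 29 percentage points lower from compound 1 to compound 3 (beyond the scatter), so both amides in the series sit beyond the scatter from the acid and no compound shown goes against that. No measurement available here accounts for these numbers.

From the compounds shown here alone, it remains open how a carboxylic acid on the three-membered ring would compare with the carbamoyl group of compound 3. Going by these compounds, the response of the opposite stereoisomer of 2-carbamoylcyclopropyl also remains open.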